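Amidine series: methylpiperazinyl substitution on the aniline ring

This account rests on a few compounds, and the source may have more. Where it says the series, first, only, none or still open, it means among the compounds named here.

Measured compounds, values in a functional assay on HT-1080 cells (Homo sapiens) for cytotoxicity, read by MTT assay, with a stated time of 72 h; on this read-out lower numbers stand for stronger inhibition and higher numbers for weaker inhibition:
compound 1 `N=C(Nc1cccc(C(F)(F)F)c1)c1cc2c(-c3ccccc3)n[nH]c2cn1`: 24600 nM
compound 2 `N=C(Nc1ccccc1)c1cc2c(-c3ccccc3)n[nH]c2cn1`: 22000 nM
compound 3 `Cn1nc(-c2ccccc2)c2cc(C(=N)Nc3ccccc3)ncc21`: 17400 nM

Compound 2 stands second highest of the three numbers in this assay; its nearest neighbour is compound 1, its furthest compound 3, and both lie within the scatter of it. The two steps seen so far, a 1.1-fold lower number from compound 1 to compound 2 (0.05 log units; within the scatter) and a 1.3-fold lower number from compound 2 to compound 3 (0.10 log units; within the scatter), are both within the scatter, so no change made so far has moved this assay.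

Compound 4 `CN1CCN(c2ccc(NC(=N)c3cc4c(-c5ccccc5)n[nH]c4cn3)cc2)CC1` differs from compound 2 by 4-methylpiperazin-1-yl in place of hydrogen on an aromatic carbon. Going by the values given here, the only step on the same ring is a 1.1-fold lower number from compound 1 to compound 2 (0.05 log units; within the scatter), which was within the scatter; no step on the series covers the entering group. No step beyond the scatter is therefore expected in this assay, with at most a slight lowering of the number.

For compound 4 the expected value in this assay is 15000 nM, estimated to lie between 5000 nM and 45000 nM, which would mean a step of a 1.5-fold lower number from compound 2 to compound 4 (0.17 log units; within the scatter).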

Compound 4, half-maximal inhibitory concentration: 11400 nM
Compound 4: the middle estimate sits 1.3-fold (0.12 log units) above what was measured, within the range that was stated.
By their numbers in this assay, from the lowest: compounds 4, 3, 2 and 1 (each within the scatter of the next, the first and the last beyond it).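

Placed on the aromatic carbon para to a large group, 4-methylpiperazin-1-yl, with its 7 heavy atoms and non-aromatic ring, is the first large substituent on this ring, and in this assay it gives a 1.9-fold lower number from compound 2 to compound 4 (0.29 log units; within the scatter). The earlier step on this ring involved only trifluoromethyl and hydrogen, so this result extends the tolerated change to a much larger group: the number does not rise, and the step cannot be read as a real gain in cytotoxicity. No measurement bearing on the origin of this result is available.

Going by these compounds, whether the methyl on the piperazine matters remains open, as a plain piperazine or a morpholine at this position would show. Also open, on these data alone, is how 4-methylpiperazin-1-yl behaves on the core carrying methyl on the aromatic nitrogen, as in compound 3.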